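Aryl swap on the sulfonyl sulfur in a sulfonamide series

The source may report more compounds than this note shows. Statements on the series, on what has been measured and on what is new or still open speak of the compounds shown alone.

Compound 1 `O=[N+]([O-])c1ccc(S(=O)(=O)NCCCCCCNCc2ccc(Br)cc2)cc1` is the reference point. Within the data shown here, in a functional assay on MIA PaCa-2 cells (Homo sapiens) for inhibition, read by MTT assay, with a stated time of 72 h (on this read-out higher numbers stand for weaker inhibition of growth and lower numbers for stronger inhibition of growth), compound 1 gives 9800 nM, the highest of the three numbers measured so far. Compound 2 `O=S(=O)(NCCCNCc1ccc(Cl)c(C(F)(F)F)c1)c1cc(C(F)(F)F)cc(C(F)(F)F)c1` gives 7400 nM in this assay, a number within the scatter of compound 1. Compound 3 `O=S(=O)(NCCCNCc1cccc(Cl)c1)c1cc(C(F)(F)F)cc(C(F)(F)F)c1` gives 4400 nM in this assay, and the gap from compound 1 to compound 3 lies beyond the scatter. Among the measured compounds shown here, the one measured step, a 1.7-fold lower number from compound 2 to compound 3 (0.23 log units; within the scatter), concerns the aryl on the saturated chain carbon bound to an amine nitrogen and is within the scatter.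

Compound 4 `O=S(=O)(NCCCCCCNCc1ccc(Br)cc1)c1ccccc1Cl` differs from compound 1 on the sulfonyl sulfur: 2-chlorophenyl in place of 4-nitrophenyl on a sulfonyl sulfur. The rest of compound 1 is kept. For the measured compounds named here, no measured pair in this set changes the aryl on the sulfonyl sulfur, so the step from compound 2 to compound 3 cannot be carried over directly; it shows only that changing an aryl elsewhere left the number within the scatter. All three measured numbers fall in a narrow band, and compound 4 is expected to remain near compound 1. For compound 4 the expected step is a 1.2-fold lower number from compound 1 to compound 4 (0.09 log units; within the scatter), not beyond the scatter. Compound 4 is estimated at 8000 nM, with a range from 3000 nM to 25000 nM.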

Compound 4, concentration for 50% growth inhibition: 13700 nM
Compound 4: the middle estimate sits 1.7-fold (0.23 log units) below what was measured; the measured number falls inside the stated range.
By their numbers in this assay, from the lowest: compounds 3, 2, 1 and 4 (each within the scatter of the next, the first and the last beyond it).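

In this assay, among these compounds, the first measured change of the aryl on a sulfonyl sulfur gives a 1.4-fold higher number from compound 1 to compound 4 (0.15 log units; within the scatter) and so does not separate 2-chlorophenyl from 4-nitrophenyl at this position. The two groups are not close in what is counted for them: 4-nitrophenyl has 9 heavy atoms and 2 hydrogen-bond acceptors, whereas 2-chlorophenyl has 7 heavy atoms, including a chlorine, and 0 hydrogen-bond acceptors, yet on the core of compound 1 this exchange leaves the number within the scatter. No measured evidence on any property of these groups bears on this result, so the step stands as an observation without an explanation.

Among the compounds shown here, this single pair covers only two aryl groups on the sulfonyl sulfur, both on the chain and bromophenyl end of compound 1, and it does not show whether the same exchange would stay within the scatter with the shorter chain of compound 2 and compound 3. Also open, as far as these compounds go, is whether an aryl carrying a carboxylic acid or an amine on the sulfonyl sulfur, or a sulfonyl sulfur bearing a plain alkyl chain, would give a step beyond the scatter.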